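The source may hold more compounds than are shown below. What is called first, only, known or untested is meant among the compounds shown, and "the series" means these compounds.

Working notes on the series. The shared core carries a branched side chain whose terminal group varies. In a functional assay on CHO cells for antagonist activity at prostaglandin E2 receptor EP3 subtype (Homo sapiens), read by cAMP accumulation (a lower number here means a stronger inhibitor, a higher number a weaker inhibitor), compound 1 `CC(C)C(Nc1nccs1)c1ccc(-c2ccc3cccc(F)c3c2)[nH]c1=O` gives 10 nM. Compound 2 `CC(C)C(/C=C1\CCNC1=O)c1ccc(-c2ccc3cccc(F)c3c2)[nH]c1=O` gives 8.7 nM in this assay; compound 3 `CC(C)C(CC(N)=O)c1ccc(-c2ccc3cccc(F)c3c2)[nH]c1=O` gives 53 nM, the highest number of the three, beyond the scatter from both others. The steps of a 5.3-fold higher number from compound 1 to compound 3 (0.72 log units; beyond the scatter) and a 6.1-fold higher number from compound 2 to compound 3 (0.78 log units; beyond the scatter) both mark carbamoylmethyl as the weaker choice at this position. Compound 4 `CC(C)C(Nc1nnc[nH]1)c1ccc(-c2ccc3cccc(F)c3c2)[nH]c1=O` differs from compound 3 by (4H-1,2,4-triazol-3-yl)amino in place of carbamoylmethyl on a saturated chain carbon bound to an aromatic carbon and a saturated chain carbon. This restores an amino-linked five-membered aromatic ring, as in compound 1, whose (1,3-thiazol-2-yl)amino gave 10 nM; the step of a 5.3-fold higher number from compound 1 to compound 3 (0.72 log units; beyond the scatter) is therefore expected to be largely reversed. Compound 4 is thus expected to give 15 nM, between 5 nM and 45 nM. The expected step is a 3.5-fold lower number from compound 3 to compound 4 (0.55 log units; beyond the scatter), a lower number.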

Compound 4, half-maximal inhibitory concentration: 185 nM
Beside the measured number, compound 4's estimate is 12-fold (1.09 log units) below it; the whole stated range lies below it.
By their numbers in this assay, from the lowest: compounds 2 and 1 (each within the scatter of the next); then compound 3; then compound 4.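

The amino link and a five-membered aromatic ring do not by themselves secure potency at this position: 4H-1,2,4-triazol-3-yl in place of 1,3-thiazol-2-yl on the amine nitrogen gives a 19-fold higher number from compound 1 to compound 4 (1.27 log units; beyond the scatter), with the amine link unchanged. The triazole group also falls behind the open-chain carbamoylmethyl, with a 3.5-fold higher number from compound 3 to compound 4 (0.54 log units; beyond the scatter), and behind the group with a five-membered non-aromatic ring, with a 21-fold higher number from compound 2 to compound 4 (1.33 log units; beyond the scatter). No measurement available here accounts for this loss. Still open, from the compounds shown here alone, is whether the loss tracks the ring nitrogens: 1,3-oxazol-2-yl or imidazol-2-yl on the same amine nitrogen would test this.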